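Ethoxycarbonyl for Methoxycarbonyl on a Piperidine Carbamate

This account rests on a few compounds, and the source may have more. Where it says the series, first, only, none or still open, it means among the compounds named here.

Compound 1, `Cc1c(Oc2ccc(/C=C3\SC(=O)NC3=O)cc2)ncnc1OC1CCN(C(=O)OCc2ccccc2)CC1`, gives 43.3% in a functional assay on CHO-K1 cells for agonist activity at Glucose-dependent insulinotropic receptor (Homo sapiens), read by cAMP accumulation and immunoassay, with a stated time of 1 h; on this read-out higher numbers stand for larger maximal responses and lower numbers for smaller maximal responses. Compound 2, `COC(=O)N1CCC(Oc2cc(Oc3cccc(/C=C4\SC(=O)NC4=O)c3)ncn2)CC1`, gives 33.7%.

Compound 2 holds the lower of these two numbers, but compound 1 lies within the usual scatter of it, so the two cannot be told apart. Compound 3, `CCOC(=O)N1CCC(Oc2cc(Oc3cccc(/C=C4\SC(=O)NC4=O)c3)ncn2)CC1`, differs from compound 2 only by methyl in place of hydrogen on a saturated chain carbon bound to an oxygen next to a carbonyl group. Going by the values given here, no step between two measured compounds is available to gauge a change of this kind, and a one-carbon growth of the carbamate is expected to bring no step beyond the scatter, so the estimated step of a number 1.3 percentage points higher from compound 2 to compound 3 (within the scatter) is small. Compound 3 is therefore expected to give 35%, between 20% and 50%.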

Compound 3, largest response reached (Emax), in percent of the reference or control that the assay uses: 43.3%
Beside the measured number, compound 3's estimate is 8.3 percentage points below it; the range from low to high includes it.
By their numbers in this assay, from the lowest: compounds 2, 1 and 3 (each within the scatter of the next).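

Going by these compounds alone, the first direct reading at this position comes in this assay, where methyl in place of hydrogen on a saturated chain carbon bound to an oxygen next to a carbonyl group gives a number 9.6 percentage points higher from compound 2 to compound 3 (within the scatter) for the change. On this read-out, methoxycarbonyl and ethoxycarbonyl therefore cannot be told apart. No other measurement bears on this result.

As far as these compounds go, what a longer chain, such as propoxycarbonyl, or an amine at this place would give remains open, as does whether any change here can produce a step beyond the scatter.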